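Pyridinyl in Place of Methylsulfonyl on a Heteroaryl Ketone

The compounds below may be only part of what the source reports. "The series", "measured", "known", "first", "only" and "open" are said of these compounds alone.

Three compounds have been measured in an assay on HEK-293T cells for inhibition of diacylglycerol lipase-alpha (Homo sapiens), read by colorimetric assay; a lower number here means a stronger inhibitor, a higher number a weaker inhibitor:
compound 1, `O=C(CCCCCc1ccccc1)c1nc2cc([N+](=O)[O-])ccc2o1`, 891 nM
compound 2, `O=C(CCCCCCc1ccccc1)c1nnc(-c2ccco2)s1`, > 10000 nM
compound 3, `CS(=O)(=O)c1coc(C(=O)CCCCCCc2ccccc2)n1`, 389 nM

All three share a ketone linking a phenyl-terminated chain to a five-membered aromatic core. Among the numbers obtained, compound 3 gives the lowest value in this assay; its nearest neighbour is compound 1, whose value is higher by a margin that lies beyond the usual scatter. For compound 2 the result is not a number but the limit of the assay, (the limit of > 10000 nM in this assay, at which 1 of the 3 values shown sits), so its value is only known to lie at or beyond that bound.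

Compound 4, `O=C(CCCCCCc1ccccc1)c1nc(-c2ccncc2)co1`, has not yet been measured. It differs from compound 3 in one place: pyridin-4-yl in place of methylsulfonyl on an aromatic carbon. For the measured compounds named here, with no step between measured compounds to lean on, the size of this change can only be guessed. The replacement of a small, non-aromatic group by an aromatic ring on the core is a substantial alteration, and the expected step is a 2.3-fold higher number from compound 3 to compound 4 (0.36 log units; beyond the scatter), toward a weaker result. Compound 4 is therefore estimated to give 900 nM in this assay, with a range from 150 nM to 6000 nM.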

Compound 4, half-maximal inhibitory concentration: > 10000 nM
Compound 4 gave a limit, no number; the forecaster's own chance of this, stated with the estimate: 15%; middle value at least 11-fold (1.04 log units) from the limit.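

In this assay, putting pyridin-4-yl in place of methylsulfonyl on the aromatic carbon next to the ring nitrogen gives an at least 25-fold higher number from compound 3 to compound 4 (1.41 log units; beyond the scatter), the only step shown between compounds that differ in one place. Compound 4 gives > 10000 nM, which is a limit of the assay and not a number, so the step marks a bound rather than an exact size: the limit of > 10000 nM in this assay, at which 2 of the 4 values shown sit.
The position is thus shown to be sensitive to what it carries, for the shared core with its phenyl-terminated chain keeps a measurable value with methylsulfonyl, compound 3 giving 389 nM, and loses it with pyridin-4-yl.

The compounds shown leave open whether the loss goes with the arrival of an aromatic ring at this carbon or with the departure of methylsulfonyl, a single pair being unable to separate the two. From the compounds shown here alone, how a phenyl ring, a nitrile or a carboxylic acid on the same carbon would read in this assay remains unknown, as does whether a shorter chain would change the size of this step.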